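Replacing a fluoropyridine with a vinyl group

The source may hold more compounds than are shown below. What is called first, only, known or untested is meant among the compounds shown, and "the series" means these compounds.

Measured in a functional assay on KYSE-70 cells for antiproliferative activity against KYSE-70 cell line (Homo sapiens), read by MTT assay, with a stated time of 72 h; a lower number here means a stronger inhibitor, a higher number a weaker inhibitor:
Compound 1 `O=C(Nc1cccc(F)c1)c1cc(=O)[nH]c2cc(C3=CCOCC3)ccc12`: 10500 nM
Compound 2 `O=C(Nc1cccc(F)c1)c1cc(=O)[nH]c2cc(-c3cccnc3F)ccc12`: > 20000 nM (a limit of the assay)

On the numbers shown, compound 2 gives > 20000 nM, which is a limit and not a number. It stands at the limit of > 20000 nM in this assay, at which 1 of the 2 values shown sits. Compound 3 `C=Cc1ccc2c(C(=O)Nc3cccc(F)c3)cc(=O)[nH]c2c1` differs from compound 2 in one place, with vinyl in place of 2-fluoropyridin-3-yl on an aromatic carbon.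

For the measured compounds named here, only one measured step bears on this change, an at least 1.9-fold higher number from compound 1 to compound 2 (0.27 log units; that floor lies within the scatter). It also exchanges the ring group at this spot, but its floor sets no firm size for such a change. Going by the values given here, the only true number available is therefore the one from compound 1, at 10500 nM, and the expectation rests on it. A change of modest size is expected in this assay, toward a lower number, with a real chance that the result is again only a limit. The estimated step is an at least 1.5-fold lower number from compound 2 to compound 3 (0.18 log units; that floor lies within the scatter). Compound 3 is expected at 13000 nM, with an estimated range from 5000 nM to 30000 nM.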

Compound 3, half-maximal inhibitory concentration: 9700 nM
Compound 3: middle estimate off by 1.3-fold (0.13 log units), on the high side, and the stated range covers the measured number.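

In this assay, for the compounds shown here, moving to the much smaller vinyl group gives an at least 2.0-fold lower number from compound 2 to compound 3 (0.31 log units; beyond the scatter), the first step at this aromatic carbon that clears the scatter, so the 2-fluoropyridin-3-yl group is not needed here for activity. On these data alone, the true size of that step stays unknown, as compound 2 is recorded only as a limit of the assay: the limit of > 20000 nM in this assay, at which 1 of the 3 values shown sits. The other comparison gives a 1.1-fold lower number from compound 1 to compound 3 (0.03 log units; within the scatter), so vinyl, with no ring, and the six-membered non-aromatic ring of compound 1 cannot be told apart in this assay, and a ring at this spot is not required to reach this level of activity.

The compounds shown leave open whether any group at this position can bring the number far lower than the level shared by compound 1 and compound 3. An ethyl group would test whether the double bond of vinyl matters, while an amine, a carboxylic acid or a longer chain such as butyl would show how much other kinds of group at this carbon can change the result.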